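The compounds below may be only part of what the source reports. "The series", "measured", "known", "first", "only" and "open" are said of these compounds alone.

Measured so far in an assay on Sf9 cells for inhibition of serine/threonine-protein kinase 4 (Homo sapiens), read by luminescence and ADP-Glo, with a stated time of 1 h, in the presence of a further agent that is not named here; on this read-out lower numbers stand for stronger inhibition and higher numbers for weaker inhibition:
Compound 1, `CC(C)C1C(=O)N(C)c2cnc(Nc3ccc(S(N)(=O)=O)cc3)nc2N1C`: 254 nM
Compound 2, `CN1C(=O)C(c2ccccc2Cl)N(C)c2nc(Nc3ccc(S(N)(=O)=O)cc3)ncc21`: 129 nM

For the measured compounds named here, compound 2 stands with the lower of the two numbers in this assay, but the only measured step, a 2.0-fold lower number from compound 1 to compound 2 (0.29 log units; within the scatter), is within the scatter, so the two compounds cannot be ranked against each other. Compound 3, `CN1C(=O)C(c2cccs2)N(C)c2nc(Nc3ccc(S(N)(=O)=O)cc3)ncc21`, differs from compound 2 in one place: thiophen-2-yl in place of 2-chlorophenyl on a saturated ring carbon. Going by the values given here, no measured pair exchanges one aromatic ring for another, so the only step that bears on this change is the one from compound 1 to compound 2, which also alters the group on that saturated ring carbon and moved the number by no more than the scatter. The expected step is therefore a 1.4-fold higher number from compound 2 to compound 3 (0.14 log units; within the scatter) in this assay, with no direction that can be trusted. Compound 3 is expected to give 180 nM in this assay, with a range of 60 nM to 500 nM.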

Compound 3, half-maximal inhibitory concentration: 88 nM
Beside the measured number, compound 3's estimate is 2.0-fold (0.31 log units) above it; the range from low to high includes it.
By their numbers in this assay, from the lowest: compounds 3, 2 and 1 (each within the scatter of the next, the first and the last beyond it).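

At the saturated ring carbon, in this assay, exchanging one aromatic ring for another gives no separable change: a 1.5-fold lower number from compound 2 to compound 3 (0.17 log units; within the scatter). Against isopropyl, however, this position now shows its first step beyond the scatter, a 2.9-fold lower number from compound 1 to compound 3 (0.46 log units; beyond the scatter), though it is modest and 2-chlorophenyl remains within the scatter of isopropyl, so the separation holds for thiophen-2-yl alone. Nothing available explains these numbers.

The compounds shown leave open whether an unsubstituted phenyl, a pyridine ring or thiophen-3-yl at this carbon would give numbers close to those of compound 2 and compound 3. They also leave open how an amine, a carboxylic acid or a longer alkyl chain would read out at the same place.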